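The source may report more compounds than this note shows. Statements on the series, on what has been measured and on what is new or still open speak of the compounds shown alone.

Measured in a functional assay on MGC-803 cells (Homo sapiens) for antiproliferative activity, read by CellTiter-Glo, with a stated time of 72 h; on this read-out higher numbers stand for weaker inhibition and lower numbers for stronger inhibition:

- compound 1 `O=C(NO)c1cccc(/C=C/c2ccnc(-c3cc(F)ccc3O)c2)c1` gives 2710 nM
- compound 2 `O=C(NO)c1cccc(/C=C/c2ccnc(-c3ccccc3O)c2)c1` gives 2810 nM
- compound 3 `COc1ccccc1-c1cc(/C=C/c2ccc(C(=O)NO)cc2)ccn1` gives 6350 nM

Compound 3 has the highest number of the three, so it sits at the weak end of this small set. Compound 4 `O=C(NO)c1ccc(/C=C/c2ccnc(-c3cccc(CO)c3)c2)cc1` has 3-(hydroxymethyl)phenyl in place of 2-methoxyphenyl on an aromatic carbon, next to the ring nitrogen: 3-(hydroxymethyl)phenyl in place of 2-methoxyphenyl on an aromatic carbon. Among the compounds with values here, no measured step covers this exchange. Within the data shown here, the only measured step, a 1.0-fold higher number from compound 1 to compound 2 (0.02 log units; within the scatter), is hydrogen in place of fluoro on an aromatic carbon, and it lies within the scatter. It gives weak support at best, as it shows one small change on that aromatic ring leaving the number in place. Taking compound 3 at 6350 nM as the starting point, no step beyond the scatter is expected in this assay. The expected step is small, a 1.3-fold lower number from compound 3 to compound 4 (0.12 log units; within the scatter), and its direction is uncertain. Compound 4 is estimated at 4800 nM, with an expected range from 1700 nM to 13000 nM.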

Compound 4, half-maximal inhibitory concentration: 1740 nM
Compound 4: the middle estimate sits 2.8-fold (0.44 log units) above what was measured; the measured number falls inside the stated range.
By their numbers in this assay, from the lowest: compounds 4, 1 and 2 (each within the scatter of the next); then compound 3.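

In this assay the exchange of 2-methoxyphenyl for 3-(hydroxymethyl)phenyl, on the aromatic carbon next to the ring nitrogen, gives a clear step (a 3.6-fold lower number from compound 3 to compound 4 (0.56 log units; beyond the scatter)), so the group at this position can move the number beyond the scatter. The step between the earlier pair (a 1.0-fold higher number from compound 1 to compound 2 (0.02 log units; within the scatter)) stayed within the scatter and involved only a fluoro on that aromatic ring, whereas here the entering group carries a hydrogen-bond donor and the leaving group carries none. No measurement at hand accounts for the step.

Open, going by these compounds, is whether the lower number follows the hydroxymethyl group itself or its place on the phenyl ring, as this pair shows methoxy and hydroxymethyl at one place each. Also open, on these data alone, is how an amine, a carboxylic acid or a longer chain such as hydroxyethyl would compare with hydroxymethyl.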